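Two chlorophenyl triazoles on a sulfonamide core, and a fourth

The source may hold more compounds than are shown below. What is called first, only, known or untested is meant among the compounds shown, and "the series" means these compounds.

Measured so far:
compound 1 `O=c1[nH]cc(S(=O)(=O)Nc2ccccc2-c2cn(-c3ccccc3Cl)nn2)c(=O)[nH]1` 2740 nM
compound 2 `O=c1[nH]cc(S(=O)(=O)Nc2ccccc2-c2cn(-c3cccc(Cl)c3)nn2)c(=O)[nH]1` 2340 nM
compound 3 `O=c1[nH]cc(S(=O)(=O)Nc2ccc(-c3cn(-c4ccccc4Cl)nn3)cc2)c(=O)[nH]1` 2810 nM

The three compounds were tested in a functional assay on A549 cells (Homo sapiens) for antiproliferative activity, read by MTT assay, with a stated time of 24 h; a lower number here means a stronger inhibitor, a higher number a weaker inhibitor. Compound 1 gives 2740 nM and compound 2 gives 2340 nM. The change between them is 3-chlorophenyl in place of 2-chlorophenyl on an aromatic nitrogen, and its step is a 1.2-fold lower number from compound 1 to compound 2 (0.07 log units; within the scatter). Compound 3 gives 2810 nM. The difference between the core of compound 3 and the core of compound 1 is not broken down here; all that can be said is that the two values lie within the scatter of each other, as do those of compound 3 and compound 2. Among the measured compounds shown here, no compound can be called stronger or weaker than another on this evidence.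

Compound 4 `O=c1[nH]cc(S(=O)(=O)Nc2ccc(-c3cn(-c4cccc(Cl)c4)nn3)cc2)c(=O)[nH]1` has not yet been measured. It differs from compound 3 by 3-chlorophenyl in place of 2-chlorophenyl on an aromatic nitrogen, which is the same change as that made from compound 1 to compound 2, at the same place on the ring. Because that earlier step was a 1.2-fold lower number from compound 1 to compound 2 (0.07 log units; within the scatter), the expected step in this assay from compound 3 is also small, a 1.1-fold lower number from compound 3 to compound 4 (0.05 log units; within the scatter), and the expectation rests on a single precedent. On this basis compound 4 is estimated to give 2500 nM, with a range from 1300 nM to 4800 nM.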

Compound 4, half-maximal inhibitory concentration: 2310 nM
For compound 4 the middle estimate is 1.1-fold (0.03 log units) above the measured one, and the stated range covers the measured number.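

In this assay, 3-chlorophenyl in place of 2-chlorophenyl on the second core gives a 1.2-fold lower number from compound 3 to compound 4 (0.09 log units; within the scatter), and set beside the earlier step, the change reads alike on the two cores: the same change on two cores in this assay, a 1.2-fold lower number (0.07 log units; within the scatter) from compound 1 to compound 2 and a 1.2-fold lower number (0.09 log units; within the scatter) from compound 3 to compound 4, 1.0-fold (0.02 log units) apart, within the scatter of two such steps

So far as these four compounds go, the swap of 2-chlorophenyl for 3-chlorophenyl carries from one core to the other in the plain sense that neither core shows a step larger than the scatter. This is agreement between two steps that are each indistinguishable from no change, and it does not show that a step of real size would transfer between these cores, nor does it say anything about cores or changes beyond the two pairs shown.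

The compounds shown leave open whether any other group on that aromatic nitrogen, such as 4-chlorophenyl, an unsubstituted phenyl, or a phenyl carrying an amine or a carboxylic acid, would give a step beyond the scatter on either core. Also open, as far as these compounds go, is whether the same picture holds in another cell line or at another exposure time.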